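From 2-methylphenyl to 4-(tert-butyl)phenyl on the sulfonamide

A few compounds are considered here, and "the series" means these few. Any claim that something is new, unique, unknown or untested is made for them only; others in the source may bear on it.

Values measured so far in a functional assay on K562 cells (Homo sapiens) for inhibition, read by CCK-8 assay, with a stated time of 72 h; a lower number here means a stronger inhibitor, a higher number a weaker inhibitor
Compound 1 `O=C(/C=C/c1cccnc1)NCCCCCc1ccc(S(=O)(=O)Nc2ccccc2)cc1` gives 146 nM
Compound 2 `Cc1ccccc1NS(=O)(=O)c1cccc(CCCCCCNC(=O)/C=C/c2cccnc2)c1` gives 0.456 nM

Of the two measured compounds, compound 2 holds the lower number (0.456 nM) and is the stronger inhibitor, compared with compound 1 (146 nM). That gap lies beyond the scatter. The next compound, compound 3 `CC(C)(C)c1ccc(NS(=O)(=O)c2cccc(CCCCCCNC(=O)/C=C/c3cccnc3)c2)cc1`, carries 4-(tert-butyl)phenyl in place of 2-methylphenyl on a sulfonamide nitrogen. For the measured compounds named here, no two measured compounds differ in one place only, so the data give no direct measure of this replacement. A modest weakening in this assay is expected, since compound 2 already reads 0.456 nM and a new group has more room to raise that number than to lower it. The expected move is a small rise (a 3.3-fold higher number from compound 2 to compound 3 (0.52 log units; beyond the scatter)). Compound 3 is expected to read 1.5 nM (estimated range 0.2 nM to 12 nM).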

Compound 3, half-maximal inhibitory concentration: 24.7 nM
Estimate against measurement, compound 3: 16-fold (1.22 log units) below; measured number outside the range, above it.
By their numbers in this assay, from the lowest: compound 2; then compound 3; then compound 1.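

For the compounds shown here, compound 2 and compound 3 form the first pair that differs in one place only, and in this assay putting 4-(tert-butyl)phenyl in place of 2-methylphenyl on the sulfonamide nitrogen gives a 54-fold higher number from compound 2 to compound 3 (1.73 log units; beyond the scatter) in a single change. The number at this position therefore depends strongly on the group carried there, even though both groups are all-carbon, hold one six-membered aromatic ring, and have no hydrogen-bond donors, acceptors or net charge. Nothing at hand accounts for the size of this step.

The two compounds cannot separate the loss of 2-methylphenyl from the gain of 4-(tert-butyl)phenyl, and compound 1, with its plain phenyl, differs elsewhere as well. From the compounds shown here alone, how a 4-methylphenyl group, a 4-chlorophenyl group or a pyridine ring would read on this nitrogen also remains open.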